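A ring swap on one aromatic carbon

This account rests on a few compounds, and the source may have more. Where it says the series, first, only, none or still open, it means among the compounds named here.

Of the compounds shown here, two that share a core have been tested so far in a functional assay on VCaP cells (Homo sapiens) for antiproliferative activity, read by CCK-8 assay, with a stated time of 6 days; a lower number here means a stronger inhibitor, a higher number a weaker inhibitor. Compound 1 `CCN(c1ccc(C#N)c(Cl)c1)c1cc(-n2cnc3ccccc32)ccc1C` gives 8560 nM. Compound 2 `CCN(c1ccc(C#N)c(Cl)c1)c1cc(-c2c[nH]nc2C)ccc1C` gives 3190 nM, the lower of the two numbers and so the stronger result. The next compound, compound 3 `CCN(c1ccc(C#N)c(Cl)c1)c1cc(-c2cccnc2)ccc1C`, keeps the shared core but carries pyridin-3-yl in place of 3-methyl-1H-pyrazol-4-yl, on an aromatic carbon para to a methyl group: pyridin-3-yl in place of 3-methyl-1H-pyrazol-4-yl on an aromatic carbon.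

For the measured compounds named here, only one measured step bears on this change. It is a 2.7-fold lower number from compound 1 to compound 2 (0.43 log units; beyond the scatter), seen when 3-methyl-1H-pyrazol-4-yl replaced 1H-benzimidazol-1-yl on that same carbon. This shows that the group at this place can move the number modestly, but nothing yet tests pyridin-3-yl here. A step of similar modest size therefore seems a fair expectation, and the direction is uncertain. Going by the values given here, compound 2 holds the better of only two values, so a slight rise is the more likely outcome. The expected change is a 1.5-fold higher number from compound 2 to compound 3 (0.18 log units; within the scatter). For compound 3 the estimate is 4800 nM, with an expected range from 1600 nM to 14000 nM.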

Compound 3, half-maximal inhibitory concentration: 1270 nM
For compound 3 the middle estimate is 3.8-fold (0.58 log units) above the measured one; measured number outside the range, below it.
By their numbers in this assay, from the lowest: compound 3; then compound 2; then compound 1.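

In this assay the aromatic carbon para to a methyl group now shows a second fall in the number, with a 2.5-fold lower number from compound 2 to compound 3 (0.40 log units; beyond the scatter) on going to pyridin-3-yl, and the whole span over the three groups is a 6.7-fold lower number from compound 1 to compound 3 (0.83 log units; beyond the scatter) on this one carbon. Pyridin-3-yl has 0 hydrogen-bond donors while 3-methyl-1H-pyrazol-4-yl has 1, so in this small set the number can fall without a donor on this ring. No measurement of any property of these groups is at hand to account for the step.

The three groups differ at once in ring size, in the number of hetero atoms and in their donors, so the compounds shown cannot separate these features from one another. Going by these compounds, it remains open how the number would respond to a plain phenyl ring, to a pyridin-3-yl ring carrying a methyl group, or to an amine or a carboxylic acid on this same carbon.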